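The source may report more compounds than this note shows. Statements on the series, on what has been measured and on what is new or still open speak of the compounds shown alone.

Among the compounds with values here, compound 3, with the structure `CCCc1cc(N)c2cc(NC(=O)/C=C/c3ccccc3Cl)ccc2n1`, sits second highest of the three numbers measured so far in a functional assay on HEK293 cells for activation of melanin-concentrating hormone receptor 1 (Homo sapiens), read by inositol phosphate accumulation (a higher number here means that more compound is needed for the effect, a lower number that less compound is needed), where compound 3 gives 500 nM. Its nearest neighbour is compound 2, structure `CCCc1cc(N)c2cc(NC(=O)/C=C/c3ccc(CC)cc3)ccc2n1`, which in this assay gives 160 nM; the furthest is compound 1, structure `CCCc1ccc(/C=C/C(=O)Nc2ccc3nc(CCC)cc(N)c3c2)cc1`, which gives 3600 nM. Compound 4, structure `CCCc1cc(N)c2cc(NC(=O)/C=C/c3ccc(I)cc3)ccc2n1`, has not yet been measured. It differs from compound 3 in one place: 4-iodophenyl in place of 2-chlorophenyl on a double-bonded chain carbon bound to a double-bonded chain carbon. Within the data shown here, two measured steps touch the same group on the same carbon. The step of a 3.1-fold higher number from compound 2 to compound 3 (0.49 log units; beyond the scatter) was modest, and the step of a 7.2-fold lower number from compound 1 to compound 3 (0.86 log units; beyond the scatter) was also modest in the opposite sense, so swapping the aryl group at that carbon has moved this assay by modest amounts either way, with the 4-ethylphenyl of compound 2 the lowest and the 4-propylphenyl of compound 1 the highest. A 4-iodophenyl is therefore expected to land somewhere between those, giving a step of a 1.7-fold lower number from compound 3 to compound 4 (0.22 log units; within the scatter). The estimate for compound 4 in this assay is 300 nM, with a range from 80 nM to 1200 nM.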

Compound 4, half-maximal effective concentration: 280 nM
Beside the measured number, compound 4's estimate is 1.1-fold (0.03 log units) above it; the measured number falls inside the stated range.
By their numbers in this assay, from the lowest: compounds 2, 4 and 3 (each within the scatter of the next, the first and the last beyond it); then compound 1.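

In this assay, the 4-iodophenyl on this double-bonded chain carbon cannot be told apart from either the 2-chlorophenyl or the 4-ethylphenyl, with a 1.8-fold lower number from compound 3 to compound 4 (0.25 log units; within the scatter) and a 1.8-fold higher number from compound 2 to compound 4 (0.24 log units; within the scatter), although those two groups do differ from each other beyond the scatter. Within the data shown here, the iodo on this aromatic carbon thus stays within the scatter of ethyl, whereas the 4-propylphenyl stands well apart, with a 13-fold lower number from compound 1 to compound 4 (1.11 log units; beyond the scatter), so a change at this ring position need not move the number far, and propyl is the one group that goes against this. No measurement is at hand that explains these steps. The compounds shown leave open whether a butyl chain on that aromatic carbon would follow propyl. They also leave open whether a 4-chlorophenyl would stay close to the 4-iodophenyl, and how an amine or a carboxylic acid there would compare.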